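The source may report more compounds than this note shows. Statements on the series, on what has been measured and on what is new or still open speak of the compounds shown alone.

Working notes on the solubility set.

Three compounds have been run in a physicochemical assay for solubility, at pH 6 (a higher number here means a more soluble compound, a lower number a less soluble compound), so far. Compound 1 `N#Cc1ccc(-c2cc(-c3ccc(C(N)=O)cc3)cc(-c3ccco3)n2)cc1` gives 10000 nM. Compound 2 `N#Cc1ccc(-c2cc(-c3ccccc3)cc(-c3ccco3)n2)cc1` gives 2000 nM. Compound 3 `N#Cc1ccc(-c2cc(-c3ccc(C(N)=O)cc3)nc(-c3ccco3)n2)cc1` gives 8000 nM, which puts it second highest of the three numbers; its nearest neighbour is compound 1, within the scatter of it, and its furthest is compound 2, which lies beyond the scatter below it.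

Within the data shown here, only one single-point step is available, and it concerns a different part of the molecule: a 5.0-fold lower number from compound 1 to compound 2 (0.70 log units; beyond the scatter), a modest move.

Compound 4 `N#Cc1ccc(-c2cc(-c3ccc(C(N)=O)cc3)nc(-c3cc[n+]([O-])cc3)n2)cc1` has not yet been measured. It differs from compound 3 in one place: a group of 7 heavy atoms (5 carbon, 1 nitrogen, 1 oxygen; one six-membered aromatic ring with 1 hetero atom) in place of a group of 5 heavy atoms (4 carbon, 1 oxygen; one five-membered aromatic ring with 1 hetero atom), on an aromatic carbon. Among the measured compounds shown here, no measured pair in this assay exchanges a five-membered aromatic ring for a six-membered one at the position between two ring nitrogen atoms, so the step from compound 1 to compound 2 offers no direct guide here. With nothing to anchor a shift in either direction, the working expectation for compound 4 in this assay is a step of a 1.5-fold higher number from compound 3 to compound 4 (0.18 log units; within the scatter), that is, a number not clearly distinguishable from compound 3 within the scatter. The estimate for compound 4 is therefore 12000 nM, with a range from 4000 nM to 35000 nM.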

Compound 4, solubility: 25000 nM
The estimate for compound 4 lay 2.1-fold (0.32 log units) below the measured number, within the range that was stated.
By their numbers in this assay, from the lowest: compound 2; then compounds 3 and 1 (each within the scatter of the next); then compound 4.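

Working notes, continued: in this assay the position between two ring nitrogen atoms proves responsive, since the exchange of furan-2-yl for the larger six-membered aromatic ring with 1 hetero atom gives a 3.1-fold higher number from compound 3 to compound 4 (0.49 log units; beyond the scatter) on the core of compound 3. Among these compounds, the only earlier step, a 5.0-fold lower number from compound 1 to compound 2 (0.70 log units; beyond the scatter), concerned the carbamoyl group at a different place, so this is the first sign that a change at this second place can also move the number beyond the scatter, here upward. No measurement in hand bears on the reason for this rise, so it stands as an observation on this one exchange.

The compounds shown do not separate the contribution of the six-membered ring from that of the oxygen on its ring nitrogen, a question that a plain pyridin-4-yl group or a phenyl group at this position would address. They also leave open whether the same exchange gives a similar step on the core of compound 1 or in the absence of the carbamoyl group, as in compound 2.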